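Permeability notes: compound 4 against compound 2

A few compounds are considered here, and "the series" means these few. Any claim that something is new, unique, unknown or untested is made for them only; others in the source may bear on it.

Compound 2 `COc1ccc(F)cc1CNCCCNc1ccnc2cc(CCc3ccccc3)ccc12` in an ADME assay for permeability, using PAMPA, with a stated time of 30 min, at pH 7.4 (on this read-out higher numbers stand for higher permeability and lower numbers for lower permeability), gives 23 10^-6 cm/s. Compound 1 `COc1ccc(F)cc1CNCCCNc1ccnc2cc(CCC(C)C)ccc12` gives 23 10^-6 cm/s and compound 3 `COc1ccc(F)cc1CNCCCNc1ccnc2cc(Cc3cccc(C(F)(F)F)c3)ccc12` gives 23 10^-6 cm/s, so compound 2 stands level with both at the digits shown, with compound 1 as its nearest and compound 3 as its furthest neighbour, neither separated from it beyond the scatter. The three measured steps all sit at the far end of the shared core: no change at the digits printed from compound 1 to compound 2 (within the scatter), no change at the digits printed from compound 1 to compound 3 (within the scatter) and no change at the digits printed from compound 2 to compound 3 (within the scatter). None of them reaches the part that changes in compound 4.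

Compound 4 `COc1cccc(CNCCCNc2ccnc3cc(CCc4ccccc4)ccc23)c1O` differs from compound 2 in one place: 2-hydroxy-3-methoxyphenyl in place of 5-fluoro-2-methoxyphenyl on a saturated chain carbon bound to an amine nitrogen. Within the data shown here, that group, on a saturated chain carbon bound to an amine nitrogen, is common to compounds 1, 2 and 3, so no measured step tells how this assay answers a change there. The measured steps only show that this assay did not move when the other end of the core was varied. Among the measured compounds shown here, with no bearing step, the expected step from compound 2 to compound 4 is a 1.3-fold lower number from compound 2 to compound 4 (0.11 log units; within the scatter), a small shift held within the scatter and carrying a wide range. For compound 4 the estimate is 18 10^-6 cm/s, expected to fall between 8 10^-6 cm/s and 32 10^-6 cm/s.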

Compound 4, apparent permeability: 23 10^-6 cm/s
Compound 4: the middle estimate sits 1.3-fold (0.11 log units) below what was measured, and the stated range covers the measured number.
By their numbers in this assay, from the lowest: compounds 1, 2, 3 and 4 (each within the scatter of the next).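

Among these compounds, the swap of 5-fluoro-2-methoxyphenyl for 2-hydroxy-3-methoxyphenyl on a saturated chain carbon bound to an amine nitrogen gives no change at the digits printed from compound 2 to compound 4 (within the scatter) in this assay and is the first reading at this position. The earlier compounds shown here showed the read-out level only for changes elsewhere on the shared core, whereas this step shows it also level across one change here, with 9 heavy atoms on both sides, the fluorine gone, and 0 hydrogen-bond donors and 1 hydrogen-bond acceptor giving way to 1 hydrogen-bond donor and 2 hydrogen-bond acceptors. No supporting data on hand offer a reason for this level result.

From the compounds shown here alone, this position is read through a single pair of substituted phenyl groups, so it remains open whether a pyridyl ring in place of the phenyl, a carboxylic acid on the ring or a longer chain carrying the ring would leave the read-out level. Going by these compounds, the swap is also read only with the rest of compound 2 in place, so its outcome with the rest of compound 1 or compound 3 remains open.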